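Ring swap on the hydroxycarbamoyl-bearing arm of compound 1

The source may hold more compounds than are shown below. What is called first, only, known or untested is meant among the compounds shown, and "the series" means these compounds.

Measured compounds:
compound 1 `COc1cc2c(NCC3CCN(c4ncc(C(=O)NO)cn4)CC3)cc(-c3ccc(C)o3)nc2cc1OCCCN1CCCC1` 152 nM
compound 2 `COc1cc2c(NCc3ccc(C(=O)NO)cc3)cc(-c3ccc(C)o3)nc2cc1OCCCN1CCCC1` 11 nM

Of the compounds shown here, two from a shared core have been tested in an assay on isolated protein for inhibition of protein deacetylase HDAC6 (Homo sapiens), read by fluorescence, with a stated time of 30 min; on this read-out higher numbers stand for weaker inhibition and lower numbers for stronger inhibition. Compound 1 gives 152 nM, the highest number of the two. Among the compounds with values here, compound 2 gives 11 nM, a number that sits well below that of compound 1, the gap lying beyond the scatter; compound 2 has no six-membered non-aromatic ring with one nitrogen in its arm, so the two differ in more than one place and no single step is drawn between them.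

Compound 3 `COc1cc2c(NCC3CCN(c4ccc(C(=O)NO)cc4)CC3)cc(-c3ccc(C)o3)nc2cc1OCCCN1CCCC1` has not yet been measured. It differs from compound 1 in one place: 4-(hydroxycarbamoyl)phenyl in place of 5-(hydroxycarbamoyl)pyrimidin-2-yl on an amine nitrogen in a ring. Compound 3 thereby carries the same 4-(hydroxycarbamoyl)phenyl group that compound 2 carries, while keeping the arm of compound 1. Within the data shown here, with no measured step of this kind available, the expectation rests on the values of compound 1 and compound 2 alone: the number for compound 3 is expected to move downward from that of compound 1, by a step of a 2.5-fold lower number from compound 1 to compound 3 (0.40 log units; beyond the scatter), but to stop short of compound 2. For compound 3 the estimate is 60 nM, within 15 nM to 250 nM.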

Compound 3, half-maximal inhibitory concentration: 67 nM
Estimate against measurement, compound 3: 1.1-fold (0.05 log units) below; the measured number falls inside the stated range.
By their numbers in this assay, from the lowest: compound 2; then compound 3; then compound 1.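

In this assay, within the data shown here, the change of ring gives the first step that can be read at a single place, a 2.3-fold lower number from compound 1 to compound 3 (0.36 log units; beyond the scatter), a modest one. It shows that on an amine nitrogen in a ring of the six-membered non-aromatic ring, the aromatic ring bearing the hydroxycarbamoyl group need not hold hetero atoms: the 4-(hydroxycarbamoyl)phenyl group, a six-membered aromatic ring of carbon only, gives the lower number, while the heavy-atom count of the group stays the same and the hydroxycarbamoyl group stays in place. No measurement accompanies this step that would tell why the number moves.

The compounds shown leave open whether one ring nitrogen is enough to raise the number, as a pyridine ring carrying the hydroxycarbamoyl group at this place would show, or whether both nitrogens of the pyrimidine are needed for the full step. They also leave open how a fluorine on the phenyl ring, or a methyl group on it, would move the number in this assay.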